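This account rests on a few compounds, and the source may have more. Where it says the series, first, only, none or still open, it means among the compounds named here.

Compound 1, `CCOC(=O)c1c(-c2ccc(Cl)c(Cl)c2)cc(-c2ccccc2)nc1N1CCCCC1`: 64.7%
Compound 2, `CCOC(=O)c1c(-c2ccc(Cl)c(Cl)c2)cc(-c2ccccc2)nc1Nc1ccc(C)cc1`: 59.8%
Compound 3, `CCOC(=O)c1c(-c2ccc(Cl)cc2)cc(-c2ccccc2)nc1Nc1ccc(Cl)cc1`: 65.2%

In a functional assay on the whole organism (strain Wister albino) for inhibition, with Rattus norvegicus as the target, read by paw edema, with stated times of 1 h and 4 h, at a dose of 50 mg/kg by the intraperitoneal route (on this read-out lower numbers stand for less inhibition and higher numbers for more inhibition at the one dose given (going by the name of the read-out)), compound 3 gives 65.2%. This lies close to compound 1 at 64.7% and to compound 2 at 59.8%, and all three numbers sit within the usual scatter of one another, so none of them can be set apart from the others.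

Compound 4, `CCOC(=O)c1c(-c2ccc(Cl)c(Cl)c2)cc(-c2ccccc2)nc1Nc1ccc(Cl)cc1`, has not yet been measured. It differs from compound 3 by chloro in place of hydrogen on an aromatic carbon. For the measured compounds named here, the only measured step, a number 4.9 percentage points lower from compound 1 to compound 2 (within the scatter), concerns the amino group on the shared core and not the chlorophenyl group, so it does not bear directly on this change. Compound 1 and compound 2 both carry the 3,4-dichlorophenyl group and give values close to that of compound 3, but each of them also differs from compound 3 in a second place, so their numbers show only that the 3,4-dichlorophenyl group has gone with values in the same region. On this basis compound 4 is expected to show no step beyond the scatter, a number 1.2 percentage points lower from compound 3 to compound 4 (within the scatter). The estimate for compound 4 is 64%, with a range from 54% to 74%.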

Compound 4, a percentage reported as inhibition, in the whole organism at one dose (the size of the read-out at that dose, not a potency): 62.4%
Beside the measured number, compound 4's estimate is 1.6 percentage points above it; the range from low to high includes it.
By their numbers in this assay, from the lowest: compounds 2, 4, 1 and 3 (each within the scatter of the next).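

In this assay, chloro in place of hydrogen, which turns 4-chlorophenyl into 3,4-dichlorophenyl, gives a number 2.8 percentage points lower from compound 3 to compound 4 (within the scatter), so this position takes a second chloro group without a step that can be told from the scatter. With the 3,4-dichlorophenyl group kept, chloro in place of methyl on an aromatic carbon gives a number 2.6 percentage points higher from compound 2 to compound 4 (within the scatter), and (4-chlorophenyl)amino in place of piperidin-1-yl gives a number 2.3 percentage points lower from compound 1 to compound 4 (within the scatter), both also within the scatter. Nothing measured here offers an explanation for these numbers.

The compounds shown leave open whether a methoxy group or an amine at this position would give a step beyond the scatter. They also leave open how a carboxylic acid in place of the ethyl ester on the shared core would read in this assay.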